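A few compounds are considered here, and "the series" means these few. Any claim that something is new, unique, unknown or untested is made for them only; others in the source may bear on it.

Compound 1 `Cc1cccc(N2C(=O)[C@H]3[C@H](ON4[C@@H]3C(=O)N(C)[C@@]43C[C@H](C)CC[C@H]3C(C)C)C2=O)c1`: 43.6%
Compound 2 `Cc1ccc(N2C(=O)[C@H]3[C@H](ON4[C@@H]3C(=O)N(C)[C@@]43C[C@H](C)CC[C@H]3C(C)C)C2=O)c(C)c1`: 57%

For the measured compounds named here, in a functional assay, read by spectrophotometry, with a stated time of 2 h, tested at 2 mg/mL (on this read-out lower numbers stand for a weaker effect and higher numbers for a stronger effect at the one concentration tested), compound 2 gives 57%, the highest of the two numbers at hand; the nearest is compound 1 with 43.6%, and the one measured step, a number 13.4 percentage points higher from compound 1 to compound 2 (beyond the scatter), lies beyond the scatter. Compound 3 `CC(C)[C@@H]1CC[C@@H](C)C[C@@]12N(C)C(=O)[C@@H]1[C@H]3C(=O)N(c4ccc5ccccc5c4)C(=O)[C@H]3ON12` has not yet been measured; it differs from compound 2 in one place: naphthalen-2-yl in place of 2,4-dimethylphenyl on an amide-type nitrogen in a ring. Going by the values given here, the only step that bears on this exchange is the one between compound 1 and compound 2, which swapped one methyl-bearing phenyl for another and was modest in size. Among the compounds with values here, the change to compound 3 brings in a second aromatic ring, which no measured pair covers, so no direction is indicated. Compound 3 is therefore expected to stay near compound 2, with an estimated step of a number 5 percentage points lower from compound 2 to compound 3 (within the scatter). The estimate for compound 3 in this assay is 52%, between 28% and 76%.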

Compound 3, a percentage reported as activity, at one concentration (the size of the read-out at that concentration, not a potency): 36.5%
For compound 3 the middle estimate is 15.5 percentage points above the measured one, and the stated range covers the measured number.
By their numbers in this assay, from the lowest: compounds 3 and 1 (each within the scatter of the next); then compound 2.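

In this assay, for the compounds shown here, naphthalen-2-yl in place of 2,4-dimethylphenyl on the amide-type nitrogen gives a number 20.5 percentage points lower from compound 2 to compound 3 (beyond the scatter) and so runs opposite to the one step seen before, showing that this position can move the read-out down as well as up. The same group in place of 3-methylphenyl gives a number 7.1 percentage points lower from compound 1 to compound 3 (within the scatter) and thus leaves compound 3 and compound 1 level, so among these three compounds only compound 2 stands apart, and a second aromatic ring brings no gain over either methyl-bearing phenyl. Nothing at hand accounts for these steps.

From the compounds shown here alone, it remains open whether the higher number of compound 2 belongs to its two methyl groups together, and how an unsubstituted phenyl, a benzyl or a cyclohexyl group on the same nitrogen would read. Going by these compounds, the read-out comes from one concentration, so it shows only a stronger or weaker effect at that concentration, and how these compounds compare at other concentrations stays open.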